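Phenylsulfonyl for methyl on the amine nitrogen

The source may hold more compounds than are shown below. What is called first, only, known or untested is meant among the compounds shown, and "the series" means these compounds.

In an ADME assay on L02 cells (Homo sapiens) for cytotoxicity, read by MTT assay, with a stated time of 24 h (a lower number here means a stronger inhibitor, a higher number a weaker inhibitor), compound 1 (`CN1C/C(=C\c2cccnc2)C(=O)/C(=C/c2ccccc2C(F)(F)F)C1`) gives 14100 nM and compound 2 (`CN1C/C(=C\c2ccncc2)C(=O)/C(=C/c2ccccc2C(F)(F)F)C1`) gives 15800 nM. Going by the values given here, compound 2 therefore stands level with the only other measured compound. Among the compounds with values here, the single measured step is a 1.1-fold higher number from compound 1 to compound 2 (0.05 log units; within the scatter), with pyridin-4-yl in place of pyridin-3-yl on a double-bonded chain carbon bound to a double-bonded ring carbon, and it lies within the scatter.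

Compound 3 (`O=C1/C(=C/c2ccncc2)CN(S(=O)(=O)c2ccccc2)C/C1=C\c1ccccc1C(F)(F)F`) has phenylsulfonyl in place of methyl on an amine nitrogen in a ring. The measured step lies at another place, so it gives neither a size nor a direction for this change. Within the data shown here, no measured compound carries anything other than methyl on that nitrogen. The data therefore offer no firm ground for a shift beyond the scatter, although the exchange is a large one and the range has to stay wide.

The step expected in this assay is a 1.3-fold lower number from compound 2 to compound 3 (0.12 log units; within the scatter), a modest estimate made without a direct guide. For compound 3 the estimated value is 12000 nM, with an expected range from 4000 nM to 36000 nM.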

Compound 3, half-maximal inhibitory concentration: 12300 nM
Compound 3: the middle estimate sits 1.0-fold (0.01 log units) below what was measured; measured number inside the range.
By their numbers in this assay, from the lowest: compounds 3, 1 and 2 (each within the scatter of the next).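

In this assay, going by these compounds alone, phenylsulfonyl in place of methyl on an amine nitrogen in a ring gives a 1.3-fold lower number from compound 2 to compound 3 (0.11 log units; within the scatter), the first reading at this position, since compounds 1 and 2 both carry methyl there and differ only in the pyridine group. The exchange replaces 1 heavy atom with 9 and adds a six-membered aromatic ring and 2 hydrogen-bond acceptors, yet the number stays within the scatter, so in this pair the size of the group on the nitrogen does not show up in the read-out. No independent measurement is available to account for this result.

As far as these compounds go, this rests on one pair only, so it remains open whether phenylsulfonyl reads the same alongside the pyridin-3-yl group of compound 1. Also open, from the compounds shown here alone, is what a benzyl group, an acetyl group, a longer alkyl chain or a phenylsulfonyl carrying a methoxy group would give on that nitrogen, and whether any group there moves the number beyond the scatter.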